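Compound 3 after two limit readings

The compounds below may be only part of what the source reports. "The series", "measured", "known", "first", "only" and "open" are said of these compounds alone.

In a functional assay on SEM cells (Homo sapiens) for cytotoxicity, with a stated time of 72 h (on this read-out lower numbers stand for an effect already at smaller amounts and higher numbers for an effect only at larger amounts of compound), compound 1 (`C=C[C@@](C)(/C=C/c1ccc(O)cc1)CCCO`) gives > 36600 nM as a limit and not a number. Compound 2 (`C=C[C@@](C)(/C=C/c1ccc(O)cc1)CC/C=C/C#N`) gives > 36600 nM in this assay and this too is a limit. Going by the values given here, the only measured step is a step that the two limits leave unreadable from compound 1 to compound 2 and no size can be drawn from it. Among the compounds with values here, the series so far amounts to the limit of > 36600 nM in this assay, at which 2 of the 2 values shown sit, and holds no numerical value.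

Compound 3 (`C=C[C@@](C)(/C=C/c1ccc(O)cc1)CC/C=C(\C)CO`) carries 2-(hydroxymethyl)prop-1-en-1-yl in place of 2-cyanoethenyl on a saturated chain carbon, three bonds along the chain from two double-bonded chain carbons. Within the data shown here, neither chain end measured so far has given a readable value, so no step of readable size and no direction is expected, although a shift cannot be excluded. The expectation rests on compound 2 and its limit of > 36600 nM alone. The expected step is a step that the limit leaves unreadable from compound 2 to compound 3 and it is an estimate with no measured size behind it. For compound 3 the estimate is 40000 nM with an expected range from 15000 nM to 80000 nM and another limit is the likeliest report.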

Compound 3, half-maximal effective concentration: > 36600 nM
Compound 3: only a limit was reported (the forecaster's own chance of this, stated with the estimate: 75%); the middle value is on the limit's open side.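

Compound 3 returns only a limit in this assay, not a number, so neither the step from compound 1 to compound 3 nor the step from compound 2 to compound 3 can be read, and the series stays at a single reading: the limit of > 36600 nM in this assay, at which 3 of the 3 values shown sit.

The compounds shown leave open whether any chain end on the shared core gives a readable value in this assay.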